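Working notes: a quaternary ammonium swap in one series

The compounds below may be only part of what the source reports. "The series", "measured", "known", "first", "only" and "open" are said of these compounds alone.

Four compounds share one core. Compound 1 `Cc1cc(OCCCCCCC[N+]23CCN(CC2)CC3)ccc1-n1cc(C(=O)Nc2cc(F)cc(F)c2)c(=O)c2ccc(N(C)C)nc21` gives "not active" (no number reported) in an assay on LX2 cells for inhibition of COL1A1 promoter (Homo sapiens), read by a luciferase reporter, with a stated time of 24 h, tested at 20 uM; on this read-out lower numbers stand for a weaker effect and higher numbers for a stronger effect at the one concentration tested. Compound 2 `CN(C)c1ccc2c(=O)c(C(=O)Nc3cc(F)cc(F)c3)cn(-c3ccc(Cl)c(OCCCCCCC[N+]45CCN(CC4)CC5)c3)c2n1` gives 8.08% in this assay, and compound 3 `Cc1cc(OCCCCCCC[N+]2(C)CCCC2)cc(-n2cc(C(=O)Nc3cc(F)cc(F)c3)c(=O)c3ccc(N(C)C)nc32)c1` gives 4.32%; these two numbers sit within the scatter of each other, so neither is set apart, and compound 1 carries no number at all. Compound 4 `CN(C)c1ccc2c(=O)c(C(=O)Nc3cc(F)cc(F)c3)cn(-c3ccc(Cl)c(OCCCCCCC[N+]4(C)CCCC4)c3)c2n1` is not yet measured. It differs from compound 2 in one place: a group of 6 heavy atoms (5 carbon, 1 nitrogen; one five-membered non-aromatic ring with 1 hetero atom) in place of a group of 8 heavy atoms (6 carbon, 2 nitrogen; 2 six-membered non-aromatic rings with 2 hetero atoms each), on a saturated chain carbon, seven bonds along the chain from an oxygen on an aromatic ring. Going by the values given here, no measured pair isolates this change. Among the compounds with values here, with only two numbers in hand, and those within the scatter, no step beyond the scatter is expected here. The expected step of a number 2.1 percentage points lower from compound 2 to compound 4 (within the scatter) is accordingly small. Compound 4 is expected to give 6%, within -4% to 16%.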

Compound 4, a percentage reported as inhibition, at one concentration (the size of the read-out at that concentration, not a potency): 51%
The estimate for compound 4 lay 45 percentage points below the measured number; measured number above the stated range.
By their numbers in this assay, from the lowest: compounds 3 and 2 (each within the scatter of the next); then compound 4.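

Replacing the group of 8 heavy atoms with the group of 6 heavy atoms at this chain end gives a number 42.9 percentage points higher from compound 2 to compound 4 (beyond the scatter) in this assay, a step beyond the scatter that the earlier numbers did not show. Both groups carry net charge +1, so this step occurs with the net charge unchanged. No supporting measurement bears on why the step occurs. From the compounds shown here alone, whether the same swap gives a comparable step with the other aromatic substitution of compound 3 remains open. Also open, going by these compounds, is how a piperidine or a longer chain would read out at this position.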